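The source may hold more compounds than are shown below. What is called first, only, known or untested is meant among the compounds shown, and "the series" means these compounds.

Measured so far:
- Compound 1, `CCCCCSc1nc2ccccc2n1CC(=O)O`: 1240 nM
- Compound 2, `CCOC(=O)CCCSc1nc2ccccc2n1CC(=O)O`: 4410 nM
- Compound 3, `O=C(O)Cn1c(SCc2ccc(Cl)cc2)nc2ccccc21`: 160 nM

All three were tested in an assay on HEK293 cells for displacement of a labelled ligand from prostaglandin D2 receptor 2 (Homo sapiens); a higher number here means a weaker inhibitor, a lower number a stronger inhibitor. Compound 3 gives the lowest of the three numbers. Its nearest neighbour is compound 1, separated by the step of a 7.8-fold lower number from compound 1 to compound 3 (0.89 log units; beyond the scatter), and its furthest is compound 2, separated by the step of a 28-fold lower number from compound 2 to compound 3 (1.44 log units; beyond the scatter). The remaining measured step, a 3.6-fold higher number from compound 1 to compound 2 (0.55 log units; beyond the scatter), concerns only the end of the chain attached to the sulfur.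

Compound 4, `O=C(O)Cn1c(SCc2cccc(Cl)c2)nc2ccccc21`, has not yet been measured in this assay. It differs from compound 3 in one place: 3-chlorophenyl in place of 4-chlorophenyl on a saturated chain carbon bound to a sulfur. Within the data shown here, none of the measured steps bears directly on this change. Among the measured compounds shown here, the two steps leading to compound 3 replace an alkyl chain with a chlorophenyl ring as a whole, and the step between compound 1 and compound 2 alters a chain end; no measured pair moves a chlorine from one ring position to another. With nothing in the data to point either way, compound 4 is expected to stay close to compound 3, with a step of a 1.3-fold higher number from compound 3 to compound 4 (0.10 log units; within the scatter) that does not go beyond the scatter. The estimate for compound 4 in this assay is 200 nM, within a range from 60 nM to 650 nM.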

Compound 4, half-maximal inhibitory concentration: 186 nM
Compound 4: middle estimate off by 1.1-fold (0.03 log units), on the high side, and the stated range covers the measured number.
By their numbers in this assay, from the lowest: compounds 3 and 4 (each within the scatter of the next); then compound 1; then compound 2.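

In this assay, among these compounds, this is the first pair that keeps the ring and alters only where the chlorine sits, and a 1.2-fold higher number from compound 3 to compound 4 (0.07 log units; within the scatter) shows that 3-chlorophenyl in place of 4-chlorophenyl on a saturated chain carbon bound to a sulfur cannot be told apart from the scatter. The clear advantage over the two chains therefore does not belong to 4-chlorophenyl alone, since 3-chlorophenyl also stands well clear of them, with a 24-fold lower number from compound 2 to compound 4 (1.37 log units; beyond the scatter) as the large step and a 6.7-fold lower number from compound 1 to compound 4 (0.82 log units; beyond the scatter) as the modest one. Nothing available explains why the two chlorophenyl groups read alike.

The compounds shown leave open whether the chlorine contributes at all, as plain phenyl is not among them, and whether 2-chlorophenyl would fit the same picture. As far as these compounds go, it also remains open whether methoxy or an amine in place of the chlorine, or a longer chain carrying the ring on the sulfur, would keep the number in the same range.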